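Furan-to-thiophene swap on two cores of the cyclic thiourea/urea series

The source may report more compounds than this note shows. Statements on the series, on what has been measured and on what is new or still open speak of the compounds shown alone.

Compound 1 `CC1=C(C(=O)OCc2ccccc2)C(c2ccoc2)NC(=S)N1` gives 36% in an assay on membranes from HEK293 cells for displacement of a labelled ligand from adenosine receptor A2b (Homo sapiens), read by scintillation counting, with a stated time of 30 min, tested at 1 uM; a lower number here means less inhibition, a higher number more inhibition at the concentration tested (going by the name of the read-out). Compound 2 `CC1=C(C(=O)OCc2ccccc2)C(c2ccsc2)NC(=S)N1` differs from it by thiophen-3-yl in place of furan-3-yl on a saturated ring carbon and gives 10% in this assay; this step gives a number 26 percentage points lower from compound 1 to compound 2 (beyond the scatter). Compound 3 `CC1=C(C(N)=O)C(c2ccoc2)NC(=O)N1` gives 6% in this assay; beside compound 2 the two values lie within the scatter, while beside compound 1 the value of compound 3 is lower. How the core of compound 3 differs from the core of compound 1 is not broken down here. Compound 4 `CC1=C(C(N)=O)C(c2ccsc2)NC(=O)N1` is not yet measured; it differs from compound 3 by thiophen-3-yl in place of furan-3-yl on a saturated ring carbon. This is the same kind of change as from compound 1 to compound 2, though the neighbouring ring atom bears a carbamoyl group (3 heavy atoms) in the pair of compound 3 and compound 4, and a large group in the pair of compound 1 and compound 2. For the measured compounds named here, only one measured instance of the change exists. For compound 4 a step of a number 3 percentage points lower from compound 3 to compound 4 (within the scatter) in this assay is expected, because compound 3 already sits at 6% and leaves little room for a drop of the size seen from compound 1 to compound 2. Compound 4 is thus estimated at 3%, between -5% and 12%.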

Compound 4, a percentage reported as inhibition, at one concentration (the size of the read-out at that concentration, not a potency): 1%
Estimate against measurement, compound 4: 2 percentage points above; the range from low to high includes it.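

The swap of furan-3-yl for thiophen-3-yl on the core of compound 3 gives a number 5 percentage points lower from compound 3 to compound 4 (within the scatter) in this assay, so the change does not carry over between the two cores at the same size: the same change on two cores in this assay, a number 26 percentage points lower (beyond the scatter) from compound 1 to compound 2 and a number 5 percentage points lower (within the scatter) from compound 3 to compound 4, 21 percentage points apart, beyond the scatter of two such steps

On the core of compound 3 the change cannot be told from the scatter, and with compound 3 at 6% the read-out leaves little room for a larger drop, so this pair does not show that the core alters the effect of the change. For the compounds shown here, with only two pairs, and with cores that differ in more than one place, the gap between the steps cannot be assigned to any single part of the core.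

Still open, going by these compounds, is whether a carboxylic acid or an ester in place of the carbamoyl group would lift the numbers on the core of compound 3 enough for the swap to be read there. Also open, on these data alone, is whether a phenyl or pyridyl ring in place of furan-3-yl would follow thiophen-3-yl on the core of compound 1.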